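Swapping methoxy for fluoro on the hydroxyphenyl ring

The source may report more compounds than this note shows. Statements on the series, on what has been measured and on what is new or still open speak of the compounds shown alone.

- compound 1 `COc1cc(C=C(C(=O)/C=C/c2cccc(OC)c2OC)C(=O)/C=C/c2cccc(OC)c2OC)ccc1O` gives 480 nM
- compound 2 `COc1cc(C=C(C(=O)/C=C/c2cccc(OC)c2OC)C(=O)/C=C/c2cccc(OC)c2OC)cc(OC)c1O` gives 460 nM
- compound 3 `COc1ccc(/C=C/C(=O)C(=Cc2ccc(O)c(OC)c2)C(=O)/C=C/c2ccc(OC)cc2OC)c(OC)c1` gives 2140 nM

In a functional assay on MCF7 cells (Homo sapiens) for antiproliferative activity, read by sulforhodamine B assay, with a stated time of 48 h (on this read-out higher numbers stand for weaker inhibition and lower numbers for stronger inhibition), compound 3 has the highest number of the three (2140 nM), and its gaps to compound 1 and to compound 2 both lie beyond the scatter, so it is the weakest inhibitor measured here. Compound 4 `COc1ccc(/C=C/C(=O)C(=Cc2ccc(O)c(F)c2)C(=O)/C=C/c2ccc(OC)cc2OC)c(OC)c1` changes a single group of compound 3: fluoro in place of methoxy on an aromatic carbon, ortho to a hydroxy group (fluoro in place of methoxy on an aromatic carbon). Going by the values given here, only one measured step touches the ring that carries this hydroxy group. That step, a 1.0-fold lower number from compound 1 to compound 2 (0.02 log units; within the scatter), adds a methoxy in place of hydrogen and stays within the scatter. Among the compounds with values here, it is a different swap, and no measured compound carries fluoro, so the guidance is thin. Still, it suggests that this ring tolerates change in this assay, so no shift beyond the scatter is expected. The expected step is a 1.1-fold lower number from compound 3 to compound 4 (0.03 log units; within the scatter), with no firm direction. For compound 4 the estimated value is 2000 nM, with an expected range from 800 nM to 5000 nM.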

Compound 4, half-maximal inhibitory concentration: 5450 nM
The estimate for compound 4 lay 2.7-fold (0.44 log units) below the measured number; the measured number lies above the stated range.
By their numbers in this assay, from the lowest: compounds 2 and 1 (each within the scatter of the next); then compound 3; then compound 4.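

In this assay the step of a 2.5-fold higher number from compound 3 to compound 4 (0.41 log units; beyond the scatter) shows that this position, ortho to a hydroxy group, is sensitive to the group it carries: the change from 4-hydroxy-3-methoxyphenyl to 3-fluoro-4-hydroxyphenyl gives modestly weaker inhibition. The earlier step on this ring, a 1.0-fold lower number from compound 1 to compound 2 (0.02 log units; within the scatter), stayed within the scatter, so the tolerance seen when a methoxy replaced hydrogen does not extend to replacing this methoxy with fluoro. Nothing in the available data explains the rise.

The compounds shown leave open whether the weaker inhibition follows from losing the methoxy or from gaining the fluoro, a question that an ethoxy group, a chlorine atom or an amine at this place could help to settle. They also leave open whether the same swap would have a similar effect on compound 1, which carries different dimethoxyphenyl groups.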